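The source may report more compounds than this note shows. Statements on the series, on what has been measured and on what is new or still open speak of the compounds shown alone.

Measured in a functional assay on A549 cells (Homo sapiens) for cytotoxicity, read by MTT assay, with a stated time of 72 h; a lower number here means a stronger inhibitor, a higher number a weaker inhibitor:
- compound 1 `O=C(N/N=C/c1ccc(F)cc1Cl)Nc1cc2c(Nc3ccc(F)c(Cl)c3)ncnc2cc1O[C@H]1CCOC1`: 27200 nM
- compound 2 `COc1ccc(/C=N/NC(=O)Nc2cc3c(Nc4ccc(F)c(Cl)c4)ncnc3cc2O[C@H]2CCOC2)c(OC)c1OC`: 25200 nM
- compound 3 `COc1cc(/C=N/NC(=O)Nc2cc3c(Nc4ccc(F)c(Cl)c4)ncnc3cc2O[C@H]2CCOC2)cc(OC)c1OC`: 26400 nM

Compound 1 stands level with the other two, as all three values lie within the scatter of each other. Compound 4 `O=C(N/N=C/c1cc(Br)c(O)c(Br)c1)Nc1cc2c(Nc3ccc(F)c(Cl)c3)ncnc2cc1O[C@H]1CCOC1` differs from compound 1 on a carbon with a double bond to nitrogen: 3,5-dibromo-4-hydroxyphenyl in place of 2-chloro-4-fluorophenyl on a carbon with a double bond to nitrogen.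

Two measured steps replace the same group: a 1.1-fold lower number from compound 1 to compound 2 (0.03 log units; within the scatter) and a 1.0-fold lower number from compound 1 to compound 3 (0.01 log units; within the scatter). Swapping one trimethoxyphenyl for the other gives a 1.0-fold higher number from compound 2 to compound 3 (0.02 log units; within the scatter). From the compounds shown here alone, all three stay within the scatter, but none introduces bromine or a hydroxyl group, so this change remains untested. No step beyond the scatter is expected in this assay.

The expected change is a 1.1-fold lower number from compound 1 to compound 4 (0.05 log units; within the scatter). Compound 4 is estimated at 24000 nM, with an expected range of 10000 nM to 50000 nM.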

Compound 4, half-maximal inhibitory concentration: 8910 nM
Compound 4: the middle estimate sits 2.7-fold (0.43 log units) above what was measured; measured number below the stated range.
By their numbers in this assay, from the lowest: compound 4; then compounds 2, 3 and 1 (each within the scatter of the next).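

In this assay this position proves responsive: 3,5-dibromo-4-hydroxyphenyl gives a 3.1-fold lower number from compound 1 to compound 4 (0.48 log units; beyond the scatter) and a 3.0-fold lower number from compound 3 to compound 4 (0.47 log units; beyond the scatter) and a 2.8-fold lower number from compound 2 to compound 4 (0.45 log units; beyond the scatter) as well. Among the compounds shown here, these are the first steps beyond the scatter at the carbon with a double bond to nitrogen, though all are modest, so the flat reading from compounds 1, 2 and 3 does not extend to compound 4. No evidence on hand bears on this result. Open, from the compounds shown here alone, is whether bromine alone, hydroxyl alone or the pair carries the step. Going by these compounds, an amine in place of the hydroxyl is equally open.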